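Halogen swap on the sulfonyl aryl of the N-benzyl sulfonamide

The source may hold more compounds than are shown below. What is called first, only, known or untested is meant among the compounds shown, and "the series" means these compounds.

Measured so far:
compound 1 `CCOC(=O)c1oc2ccc(NS(=O)(=O)c3ccc(Br)cc3)cc2c1C` — 9310 nM
compound 2 `CCOC(=O)c1oc2ccc(NS(=O)(=O)c3ccc(Cl)cc3)cc2c1C` — 24300 nM
compound 3 `CCOC(=O)c1oc2ccc(N(Cc3ccccc3)S(=O)(=O)c3ccccc3Br)cc2c1C` — > 40000 nM

All three share one core and differ in the sulfonamide part. In a functional assay on HCT-116 cells (Homo sapiens) for inhibition, read by MTT assay, with a stated time of 72 h (on this read-out higher numbers stand for weaker inhibition and lower numbers for stronger inhibition), compound 1 gives 9310 nM. Within the data shown here, compound 2 gives 24300 nM in this assay, and the only single-point step among the measured compounds, a 2.6-fold higher number from compound 1 to compound 2 (0.42 log units; beyond the scatter), runs in the direction of weaker inhibition. Compound 3 carries a benzyl group on the sulfonamide nitrogen together with a 2-bromophenyl on the sulfonyl sulfur. For compound 3 this assay reports only a limit, > 40000 nM; it is the assay's limit, not a number, and (the limit of > 40000 nM in this assay, at which 1 of the 3 values shown sits).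

Compound 4 `CCOC(=O)c1oc2ccc(N(Cc3ccccc3)S(=O)(=O)c3ccc(F)cc3)cc2c1C` is not yet measured. It differs from compound 3 in one place: 4-fluorophenyl in place of 2-bromophenyl on a sulfonyl sulfur. Among the measured compounds shown here, the only measured step, the chloro-for-bromo exchange from compound 1 to compound 2, is modest and bears on compound 4 only loosely, since it exchanges one halogen for another at a different ring position and without the benzyl on the nitrogen. With compound 3 already at the limit, the expected step of a number no higher from compound 3 to compound 4 (the limit leaves the size open) is small, and compound 4 is expected to give 40000 nM, with a range from 15000 nM to 100000 nM, most likely again only a limit in this assay.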

Compound 4, half-maximal inhibitory concentration: 5820 nM
Beside the measured number, compound 4's estimate is 6.9-fold (0.84 log units) above it; measured number below the stated range.
By their numbers in this assay, from the lowest: compounds 4 and 1 (each within the scatter of the next); then compound 2. At a limit, above all of these: compound 3.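

In this assay, the sulfonyl aryl of the N-benzyl sulfonamide proves able to move the series off the limit: 4-fluorophenyl in place of 2-bromophenyl on a sulfonyl sulfur gives an at least 6.8-fold lower number from compound 3 to compound 4 (0.83 log units; beyond the scatter). Among these compounds, the only earlier step, a 2.6-fold higher number from compound 1 to compound 2 (0.42 log units; beyond the scatter), was a halogen exchange on compounds without the benzyl on the nitrogen, so it left open whether a benzylated sulfonamide could give a readable value at all, and compound 4 shows that it can. The true size of the new step remains open, as compound 3 is held at a limit and not a number: the limit of > 40000 nM in this assay, at which 1 of the 4 values shown sits.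

The step from compound 3 to compound 4 changes the halogen and the ring position together, so the compounds shown do not tell which of the two carries the change. They also leave open how this position responds to a non-halogen substituent on the sulfonyl aryl, such as a dimethylamino group or a carboxylic acid, with the benzyl kept on the nitrogen.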